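The compounds below may be only part of what the source reports. "The series", "measured", "known", "first", "only" and "open" are said of these compounds alone.

Series notes. In an assay on isolated protein for inhibition of protein deacetylase HDAC6 (Homo sapiens), read by fluorescence, with a stated time of 1 h, tested at 100 nM (a higher number here means more inhibition at the concentration tested (going by the name of the read-out), a lower number less inhibition), compound 1 `N#Cc1ccc(CN2CCC(c3noc(COc4ccc(/C=C/C(=O)NO)cc4)n3)CC2)cc1` gives 65%. Compound 2 `CN(Cc1nc(C2CCN(Cc3ccccc3)CC2)no1)c1ncc(/C=C/C(=O)NO)cn1` gives 55% in this assay, and compound 3 `CN(Cc1nc(C2CCN(Cc3ccccc3)CC2)no1)c1ncc(C(=O)NO)cn1` gives 63%. For the measured compounds named here, the only single-point step measured, a number 8 percentage points higher from compound 2 to compound 3 (within the scatter), concerns the hydroxamate arm and not the benzyl ring. Compound 3 stands second of the three numbers, nearest compound 1 and furthest compound 2, both gaps within the scatter. Compound 4 `Cc1cccc(CN2CCC(c3noc(CN(C)c4ncc(C(=O)NO)cn4)n3)CC2)c1` differs from compound 3 by methyl in place of hydrogen on an aromatic carbon. Going by the values given here, no measured step touches the benzyl ring, so none bears directly on this change; the change is a single carbon and no shift beyond the scatter is expected, no change at the digits printed from compound 3 to compound 4 (within the scatter). Compound 4 is estimated at 63%, with a range of 50% to 76%.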

Compound 4, a percentage reported as inhibition, at one concentration (the size of the read-out at that concentration, not a potency): 54%
For compound 4 the middle estimate is 9 percentage points above the measured one, within the range that was stated.
By their numbers in this assay, from the lowest: compounds 4, 2, 3 and 1 (each within the scatter of the next, the first and the last beyond it).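

Benzyl to 3-methylbenzyl, the first measured step on this ring, reads in this assay as a number 9 percentage points lower from compound 3 to compound 4 (within the scatter) and so shows that this aromatic carbon carries a methyl without a shift beyond the scatter. This rests on one pair of compounds, and nothing on hand accounts for the step. As far as these compounds go, whether methoxy, chlorine or an amine on the same carbon would move the number beyond the scatter stays open. So does whether methyl elsewhere on the ring would read the same.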